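Hydrogen for Methyl on the Nitrogen of Compound 2

This account rests on a few compounds, and the source may have more. Where it says the series, first, only, none or still open, it means among the compounds named here.

Compound 1 `COc1ccc2c(/C=C/C(=O)c3cc(N)c(OC)c(OC)c3)cn(C)c2c1`: 356 nM
Compound 2 `COc1ccc2c(/C=C(\C)C(=O)c3cc(OC)c(OC)c([Se]C)c3)cn(C)c2c1`: 32 nM
Compound 3 `COc1ccc2c(/C=C/C(=O)c3cc(OC)c(OC)c([N+](=O)[O-])c3)c[nH]c2c1`: 850 nM

In a functional assay on HeLa cells (Homo sapiens) for antiproliferative activity, read by MTT assay, with a stated time of 48 h (a lower number here means a stronger inhibitor, a higher number a weaker inhibitor), compound 2 gives 32 nM, the lowest of the three numbers. Compound 1 and compound 3 both lie above it, by gaps beyond the usual scatter.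

Compound 4 `COc1ccc2c(/C=C(\C)C(=O)c3cc(OC)c(OC)c([Se]C)c3)c[nH]c2c1` is still unmeasured and differs from compound 2 in one place: hydrogen in place of methyl on an aromatic nitrogen.

For the measured compounds named here, no measured pair shows this change alone. Compound 3 also has hydrogen on that nitrogen and gives 850 nM, while compound 1 has methyl there and gives 356 nM. These two compounds also differ elsewhere, so their values cannot isolate the effect of this swap. The closest guide is therefore compound 2 itself.

The expected change is small and toward a higher number, about the size of the usual scatter: a 1.9-fold higher number from compound 2 to compound 4 (0.27 log units; within the scatter). For compound 4 the estimated value is 60 nM, with an expected range from 15 nM to 250 nM.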

Compound 4, half-maximal inhibitory concentration: 21 nM
For compound 4 the middle estimate is 2.9-fold (0.46 log units) above the measured one; measured number inside the range.
By their numbers in this assay, from the lowest: compounds 4 and 2 (each within the scatter of the next); then compound 1; then compound 3.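

In this assay, putting hydrogen in place of methyl on the aromatic nitrogen gives a 1.5-fold lower number from compound 2 to compound 4 (0.18 log units; within the scatter), a direct reading of this one change with everything else in the molecule held fixed. For this pair, then, the two compounds cannot be told apart, and the nitrogen of this five-membered aromatic ring can carry either methyl or hydrogen without a change that stands out from the scatter. Nothing measured here speaks to why the swap makes so little difference.

From the compounds shown here alone, whether the swap behaves the same way on the core of compound 1 or compound 3 stays open, as neither has a partner that differs from it only at this nitrogen. Also open, going by these compounds, is what an ethyl group, a longer chain or an acetyl group on this nitrogen would do.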